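Swapping the Ester Alkyl Chain: Compound 3 to Compound 4

This account rests on a few compounds, and the source may have more. Where it says the series, first, only, none or still open, it means among the compounds named here.

Of the compounds shown here, three built on one shared core have been tested in an assay on HeLa cells for displacement of a labelled ligand from adenosine receptor A3 (Homo sapiens), with a stated time of 180 min, tested at 10 uM; a higher number here means more inhibition at the concentration tested (going by the name of the read-out), a lower number less inhibition. Compound 1 `CC(=O)C1=C(C)NC(=O)NC1c1ccco1` gives 14%. Compound 2 `CC1=C(C(N)=O)C(c2ccco2)NC(=O)N1` gives 2%, and compound 3 `CCCOC(=O)C1=C(C)NC(=O)NC1c1ccco1` gives 2%, so compound 3 sits level with compound 2 at the bottom of these three numbers, with a number 12 percentage points lower from compound 1 to compound 3 (beyond the scatter) separating it from compound 1 and no change at the digits printed from compound 2 to compound 3 (within the scatter) from compound 2.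

Compound 4 `CC1=C(C(=O)OC(C)(C)C)C(c2ccco2)NC(=O)N1` differs from compound 3 only in the ester chain: tert-butyl in place of propyl on an oxygen next to a carbonyl group. For the measured compounds named here, no measured step alters the alkyl group on that oxygen; the comparisons in hand change the group on the carbonyl carbon, and compound 2 and compound 3, carrying amino or propoxy there, both sit at the low end. The step from compound 3 to compound 4 is therefore expected to stay within the scatter, as a number 1 percentage points higher from compound 3 to compound 4 (within the scatter). Compound 4 is estimated at 3%, within -8% to 15%.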

Compound 4, a percentage reported as inhibition, at one concentration (the size of the read-out at that concentration, not a potency): 7%
For compound 4 the middle estimate is 4 percentage points below the measured one; measured number inside the range.
By their numbers in this assay, from the lowest: compounds 2, 3, 4 and 1 (each within the scatter of the next, the first and the last beyond it).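

In this assay, for the compounds shown here, tert-butyl in place of propyl on an oxygen next to a carbonyl group gives a number 5 percentage points higher from compound 3 to compound 4 (within the scatter) as the first reading of a change to that alkyl group. With tert-butoxy on the carbonyl carbon the steps read a number 5 percentage points higher from compound 2 to compound 4 (within the scatter) and a number 7 percentage points lower from compound 1 to compound 4 (within the scatter) and so stay within the scatter, in contrast with a number 12 percentage points lower from compound 1 to compound 3 (beyond the scatter) for propoxy there. No measurement at hand accounts for these numbers. From the compounds shown here alone, whether a longer chain such as hexyl or a benzyl group on that oxygen would move the number beyond the scatter remains open. So does the effect of a carboxylic acid on the carbonyl carbon.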